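A few compounds are considered here, and "the series" means these few. Any claim that something is new, unique, unknown or untested is made for them only; others in the source may bear on it.

In an ADME assay on BJ cells (Homo sapiens) for cytotoxicity, with a stated time of 72 h (on this read-out lower numbers stand for an effect already at smaller amounts and higher numbers for an effect only at larger amounts of compound), compound 1 (`C=C[C@@](C)(/C=C/c1ccc(OS(=O)(=O)C(F)(F)F)cc1)CCC=C(C)C`) gives > 36600 nM, which is a limit of the assay and not a number. Compound 2 (`C=C[C@@](C)(/C=C/c1ccc(OS(=O)(=O)c2ccc(C)cc2)cc1)CCC=C(C)C`) also reaches only a limit, > 36600 nM. Compound 3 (`C=C[C@@](C)(/C=C/c1ccc(O)cc1)CCCO`) likewise gives only a limit, > 36600 nM. The whole measured picture is therefore (the limit of > 36600 nM in this assay, at which 3 of the 3 values shown sit), and compound 1 has no number against which a change could be read.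

The next structure is compound 4 (`C=C[C@@](C)(/C=C/c1ccc(Nc2ccc(F)cc2)cc1)CCC=C(C)C`), in which (4-fluorophenyl)amino stands in place of ((trifluoromethyl)sulfonyl)oxy on an aromatic carbon: (4-fluorophenyl)amino in place of ((trifluoromethyl)sulfonyl)oxy on an aromatic carbon. Among the compounds with values here, the only measured step between close relatives is a step that the two limits leave unreadable from compound 1 to compound 2, with 4-methylphenyl in place of trifluoromethyl on a sulfonyl sulfur. It exchanges a different group at a different place and has no readable size, so it offers no magnitude to carry over. With nothing measured below the limit, the expectation stays close to that limit in this assay, and a reading that again returns only a limit is quite possible. The expected change is small, an at least 1.2-fold lower number from compound 1 to compound 4 (0.08 log units; that floor lies within the scatter), and any movement is expected toward lower numbers because the data offer the limit of > 36600 nM in this assay, at which 3 of the 3 values shown sit, and nothing beneath it. For compound 4 the estimated value is 30000 nM, with an expected range from 10000 nM to 60000 nM.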

Compound 4, half-maximal effective concentration: > 36600 nM
Compound 4: a limit, no number; the forecaster's own chance of this, stated with the estimate: 60%; middle value at least 1.2-fold (0.08 log units) from the limit.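

In this assay compound 4 gives > 36600 nM, which is a limit of the assay and not a number. Within the data shown here, compound 1 also stands at a limit, so no step from it to compound 4 can be read. The compounds shown leave open what amount of any of them would bring an effect, and whether the exchanged groups make any difference, because all remain at one mark: the limit of > 36600 nM in this assay, at which 4 of the 4 values shown sit.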